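The source may report more compounds than this note shows. Statements on the series, on what has been measured and on what is new or still open speak of the compounds shown alone.

Measured so far in a functional assay on HSC-2 cells (Homo sapiens) for cytotoxicity; on this read-out higher numbers stand for lower toxicity in this test and lower numbers for higher toxicity in this test:
- compound 1 `COc1cc(/C=C2\CCC/C(=C\c3ccc([N+](=O)[O-])cc3)C2=O)ccc1O`: 2800 nM
- compound 2 `COc1cc(/C=C2\Cc3ccccc3/C(=C\c3ccc([N+](=O)[O-])cc3)C2=O)cc(OC)c1OC`: 550 nM
- compound 3 `COc1ccc(/C=C2\CCC/C(=C\c3ccc([N+](=O)[O-])cc3)C2=O)cc1OC`: 2300 nM

Compound 1 gives the highest number of the three, with compound 3 close to it and compound 2 further off. Compound 4 `O=C1/C(=C/c2ccc(O)cc2)CCC/C1=C\c1ccc([N+](=O)[O-])cc1` differs from compound 1 by hydrogen in place of methoxy on an aromatic carbon. Within the data shown here, only one measured step touches the same part of the molecule: the change of hydrogen to methyl on the ring oxygen, a 1.2-fold lower number from compound 1 to compound 3 (0.09 log units; within the scatter), which stayed within the scatter. Compound 2 differs from compound 1 in several places at once, so its lower number says nothing about this single change. The expected step is therefore no change at the digits printed from compound 1 to compound 4 (within the scatter), none beyond the scatter. Compound 4 is estimated at 2800 nM in this assay, within 1200 nM to 6500 nM.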

Compound 4, half-maximal cytotoxic concentration: 8100 nM
Compound 4: middle estimate off by 2.9-fold (0.46 log units), on the low side, and the stated range ends below it.
By their numbers in this assay, from the lowest: compound 2; then compounds 3 and 1 (each within the scatter of the next); then compound 4.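

In this assay, swapping methoxy for hydrogen on this aromatic carbon, ortho to a hydroxy group, gives a 2.9-fold higher number from compound 1 to compound 4 (0.46 log units; beyond the scatter), so this position does respond to change, towards lower toxicity in this test. The earlier change on the ring oxygen, a 1.2-fold lower number from compound 1 to compound 3 (0.09 log units; within the scatter), gave no such sign, which shows that the two sites on this ring need not behave alike. Nothing measured here bears on the reason for this rise. The compounds shown compare only hydrogen and methoxy on this carbon. From the compounds shown here alone, whether ethoxy, chlorine or an amine there would move the number the same way stays open.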